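Aryl sulfonamide in place of alkyl sulfonamide on the shared core

The compounds below may be only part of what the source reports. "The series", "measured", "known", "first", "only" and "open" are said of these compounds alone.

Measured compounds in a functional assay on A549 cells (Homo sapiens) for antiproliferative activity, read by sulforhodamine B assay, with a stated time of 72 h; a lower number here means a stronger inhibitor, a higher number a weaker inhibitor:
- compound 1 `COc1ncc(-c2ccc3ncnc(NCCN(C)C)c3c2)cc1NS(=O)(=O)c1ccc(F)cc1F`: compound 1 gives 940 nM
- compound 2 `COc1ncc(-c2ccc3ncnc(NCCCN(C)C)c3c2)cc1NS(=O)(=O)c1ccc(F)cc1F`: compound 2 gives 2780 nM
- compound 3 `CCCCS(=O)(=O)Nc1cc(-c2ccc3ncnc(NCc4ccncc4)c3c2)cnc1OC`: compound 3 gives 9420 nM

Compound 3 stands highest of the three numbers in this assay; the nearest is compound 2, and the furthest is compound 1, both beyond the scatter. For the measured compounds named here, the only single-point step measured so far is a 3.0-fold higher number from compound 1 to compound 2 (0.47 log units; beyond the scatter), which concerns the amine side chain and not the sulfonamide.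

Compound 4 `COc1ncc(-c2ccc3ncnc(NCc4ccncc4)c3c2)cc1NS(=O)(=O)c1ccc(F)cc1F` is the next compound to be measured in this assay. It differs from compound 3 by 2,4-difluorophenyl in place of butyl on a sulfonyl sulfur. Going by the values given here, no measured step bears directly on this change: compounds 1 and 2 both carry the (2,4-difluorophenyl)sulfonyl group and give lower numbers than compound 3, but they also differ from compound 3 in the side chain on the core, so their values cannot be split between the two changes. The data therefore allow only a loose expectation. Given that compounds 1 and 2 with the aryl sulfonamide sit lower, compound 4 is expected to move by a 2.7-fold lower number from compound 3 to compound 4 (0.43 log units; beyond the scatter) towards a lower number, though the gap could also fall within the scatter. Compound 4 is estimated at 3500 nM, with a range from 900 nM to 12000 nM.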

Compound 4, half-maximal inhibitory concentration: 11400 nM
The estimate for compound 4 lay 3.3-fold (0.51 log units) below the measured number, within the range that was stated.
By their numbers in this assay, from the lowest: compound 1; then compound 2; then compounds 3 and 4 (each within the scatter of the next).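

In this assay, the change from butyl to 2,4-difluorophenyl on a sulfonyl sulfur gives a 1.2-fold higher number from compound 3 to compound 4 (0.08 log units; within the scatter) with the pyridin-4-yl side chain in place, so at this position the two groups are not told apart on that side chain. With the (2,4-difluorophenyl)sulfonyl group held constant, the amine side chain does separate the compounds: pyridin-4-yl gives a 4.1-fold higher number from compound 2 to compound 4 (0.61 log units; beyond the scatter) and a 12-fold higher number from compound 1 to compound 4 (1.08 log units; beyond the scatter), which places the measured differences among these compounds at the side chain and not at the sulfonyl substituent. Nothing at hand accounts for either the flat sulfonyl step or the larger side-chain steps.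

Still open, as far as these compounds go, is whether butyl and 2,4-difluorophenyl also read alike when the sulfonamide is paired with the dimethylamino side chains of compound 1 and compound 2, since the flat step rests on a single pair on a weak background. Also open, from the compounds shown here alone, is how a longer alkyl chain, an unsubstituted phenyl or a cyclopropyl on the sulfonyl sulfur would read, and whether a morpholine or a piperidine on the side chain would follow the dimethylamino compounds.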